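The source may hold more compounds than are shown below. What is called first, only, known or untested is meant among the compounds shown, and "the series" means these compounds.

Compound 2 `CC(C)C[C@H](N)c1cc(C(F)(F)F)ccc1N1CCN(C(=O)CCC2CCCCC2)CC1` stands as the weakest inhibitor of the two compounds measured in an assay on HEK293 cells for displacement of a labelled ligand from Melanocortin receptor 4 (Homo sapiens); a lower number here means a stronger inhibitor, a higher number a weaker inhibitor: compound 2 gives 5700 nM, while compound 1 `CC(C)C[C@H](N)c1cc(C(F)(F)F)ccc1N1CCN(C(=O)C(C)Cc2ccc(Cl)cc2)CC1` gives 47 nM. Going by the values given here, the one measured step, a 120-fold higher number from compound 1 to compound 2 (2.08 log units; beyond the scatter), is the only comparison that bears on the next change. Compound 3 `Cc1cc(Cl)ccc1CC(C)C(=O)N1CCN(c2ccc(C(F)(F)F)cc2[C@@H](N)CC(C)C)CC1` is not yet measured and differs from compound 2 in this way: 1-(4-chloro-2-methylbenzyl)ethyl in place of 2-cyclohexylethyl on a carbonyl carbon The group that enters, 1-(4-chloro-2-methylbenzyl)ethyl, is a close relative of the 1-(4-chlorobenzyl)ethyl present in compound 1. A large gain in the inhibition constant is therefore expected on the way back, because the earlier step of a 120-fold higher number from compound 1 to compound 2 (2.08 log units; beyond the scatter) was large; the expected change is a 95-fold lower number from compound 2 to compound 3 (1.98 log units; beyond the scatter). For compound 3 the inhibition constant in this assay is estimated at 60 nM, with a range from 15 nM to 250 nM.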

Compound 3, inhibition constant: 38 nM
Compound 3: the middle estimate sits 1.6-fold (0.20 log units) above what was measured; the measured number falls inside the stated range.
By their numbers in this assay, from the lowest: compounds 3 and 1 (each within the scatter of the next); then compound 2.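

In this assay, the large step of a 150-fold lower number from compound 2 to compound 3 (2.18 log units; beyond the scatter) shows that replacing 2-cyclohexylethyl with 1-(4-chloro-2-methylbenzyl)ethyl on the carbonyl carbon reverses the earlier loss. The second step, a 1.2-fold lower number from compound 1 to compound 3 (0.09 log units; within the scatter), lies within the scatter, so methyl in place of hydrogen on this aromatic carbon leaves the number effectively unchanged. No supporting data explain why these groups give these numbers.

The step from compound 2 to compound 3 changes several things at once, including the ring type and the presence of chlorine and methyl, so the compounds shown cannot separate the contribution of each. On these data alone, it also remains open whether a methoxy group, an amine or a carboxylic acid on the same aromatic carbon would keep the number as close as methyl does.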